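Swapping an imidazole for bromine on a trimethoxychalcone

The source may hold more compounds than are shown below. What is called first, only, known or untested is meant among the compounds shown, and "the series" means these compounds.

Of the compounds shown here, three sharing a trimethoxyphenyl enone core have been tested in a functional assay on cells (Erythrocyte, Rattus norvegicus) for inhibition, read by hemolysis, with a stated time of 1 h; on this read-out lower numbers stand for stronger inhibition and higher numbers for weaker inhibition. Compound 1, `COc1cc(OC)c(OC)cc1/C=C/C(=O)c1cc(Cl)ccc1O`, gives 2.23 ug/mL. Compound 2, `COc1cc(OC)c(OC)cc1/C=C/C(=O)c1ccc(Cl)c([N+](=O)[O-])c1`, gives 2.15 ug/mL. Compound 3, `COc1cc(OC)c(OC)cc1/C=C/C(=O)c1ccc(-c2c[nH]cn2)cc1`, gives 2.48 ug/mL. The three numbers lie close together: the gap from compound 3 to compound 1 and the gap from compound 3 to compound 2 both fall within the usual scatter of repeated measurements, so on these data compound 3 cannot be told apart from either of the other two in this assay.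

The next compound, compound 4, `COc1cc(OC)c(OC)cc1/C=C/C(=O)c1ccc(Br)cc1`, is not yet measured. It differs from compound 3 in one place: bromo in place of 1H-imidazol-4-yl on an aromatic carbon. The group that leaves is the 1H-imidazol-4-yl; the group that enters is bromo, on an aromatic carbon of a six-membered aromatic ring of carbon only, para to a large group.

Within the data shown here, no step between measured compounds is available, and the three measured values, which carry quite different substituents on that ring, sit within the scatter of one another. The account therefore expects no step beyond the scatter in this assay, and the expected step from compound 3 to compound 4 is a 1.0-fold higher number from compound 3 to compound 4 (0.00 log units; within the scatter). Compound 4 is estimated at 2.5 ug/mL, with a range from 1.2 ug/mL to 5 ug/mL.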

Compound 4, half-maximal inhibitory concentration: 2.3 ug/mL
Compound 4: the middle estimate sits 1.1-fold (0.04 log units) above what was measured, within the range that was stated.
By their numbers in this assay, from the lowest: compounds 2, 1, 4 and 3 (each within the scatter of the next).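

In this assay, a 1.1-fold lower number from compound 3 to compound 4 (0.03 log units; within the scatter) lies within the scatter, so on this position a five-membered aromatic ring carrying a hydrogen-bond donor and a hydrogen-bond acceptor and a single bromine atom with neither cannot be told apart. Among these compounds, the result also gives the set its only measured steps, and the exchange of a whole group on the carbonyl carbon, 4-bromophenyl in place of 5-chloro-2-hydroxyphenyl, gives a 1.0-fold higher number from compound 1 to compound 4 (0.01 log units; within the scatter) and so also stays within the scatter. No accompanying measurement bears on why these numbers stay so close together.

The compounds shown leave open whether any group on this aromatic carbon can move the number beyond the scatter, for instance a carboxylic acid, a primary amine or a longer alkyl chain in place of the bromo. They also leave open whether a change to the shared core, such as the loss of one of its methoxy groups, would do what no change on the other ring has done here.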